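A Cyclopentyl Exchanged for an Aromatic Ring on a Shared Core

The compounds below may be only part of what the source reports. "The series", "measured", "known", "first", "only" and "open" are said of these compounds alone.

Of the compounds shown here, three sharing one core have been tested in a functional assay on HUVEC cells (Homo sapiens), read by scintillation counting and thymidine incorporation, with a stated time of 24 h; a lower number here means a stronger inhibitor, a higher number a weaker inhibitor. Compound 1 `CCC(C)n1ncn(-c2ccc(N3CCN(c4ccc(OC[C@@H]5CO[C@@](CBr)(c6ccc(Cl)cc6Cl)O5)cc4)CC3)cc2)c1=O` gives 569 nM. Compound 2 `CCC(C)n1ncn(-c2ccc(N3CCN(c4ccc(OC[C@@H]5CO[C@@](CC6CCCC6)(c6ccc(Cl)cc6Cl)O5)cc4)CC3)cc2)c1=O` gives 512 nM. Compound 3 `CCC(C)n1ncn(-c2ccc(N3CCN(c4ccc(OC[C@@H]5CO[C@@](CN6CCN(C)CC6)(c6ccc(Cl)cc6Cl)O5)cc4)CC3)cc2)c1=O` gives 396 nM. Compound 2 sits among the other two, nearest to compound 1 and furthest from compound 3, and the steps of a 1.1-fold lower number from compound 1 to compound 2 (0.05 log units; within the scatter) and a 1.3-fold lower number from compound 2 to compound 3 (0.11 log units; within the scatter) both fall within the scatter, as does a 1.4-fold lower number from compound 1 to compound 3 (0.16 log units; within the scatter). Exchanging the group on a saturated chain carbon bound to a saturated ring carbon has so far not moved the number beyond the scatter.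

Compound 4 `CCC(C)n1ncn(-c2ccc(N3CCN(c4ccc(OC[C@@H]5CO[C@@](Cn6cnc(C)c6)(c6ccc(Cl)cc6Cl)O5)cc4)CC3)cc2)c1=O` differs from compound 2 at that same place: 4-methyl-1H-imidazol-1-yl in place of cyclopentyl on a saturated chain carbon bound to a saturated ring carbon. All three measured steps bear on this change, since each swaps a group at this position, and none exceeded the scatter. Because the steps of a 1.1-fold lower number from compound 1 to compound 2 (0.05 log units; within the scatter), a 1.3-fold lower number from compound 2 to compound 3 (0.11 log units; within the scatter) and a 1.4-fold lower number from compound 1 to compound 3 (0.16 log units; within the scatter) were all within the scatter, compound 4 is expected to show a 1.1-fold lower number from compound 2 to compound 4 (0.06 log units; within the scatter) in this assay. Compound 4 is thus estimated to give 450 nM, with a range from 200 nM to 1000 nM.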

Compound 4, half-maximal inhibitory concentration: 102 nM
Compound 4: the middle estimate sits 4.4-fold (0.64 log units) above what was measured; the measured number lies below the stated range.
By their numbers in this assay, from the lowest: compound 4; then compounds 3, 2 and 1 (each within the scatter of the next).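

Until now every exchange at this position stayed within the scatter, so the place looked indifferent to the group it carried, but 4-methyl-1H-imidazol-1-yl breaks that picture with a 5.0-fold lower number from compound 2 to compound 4 (0.70 log units; beyond the scatter) and a 3.9-fold lower number from compound 3 to compound 4 (0.59 log units; beyond the scatter) and a 5.6-fold lower number from compound 1 to compound 4 (0.75 log units; beyond the scatter) all beyond it. The position does respond to its group, then, and the gain holds against bromo, cyclopentyl and 4-methylpiperazin-1-yl alike, the three groups that lack a five-membered aromatic ring. Nothing measured here explains why this group stands apart from the others.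

Whether the gain belongs to the aromatic ring, its two nitrogens or its methyl cannot be told from these four compounds: plain imidazol-1-yl, phenyl or 1,2,4-triazol-1-yl at this place would begin to separate them. Nor do they show how a longer chain carrying the same 4-methyl-1H-imidazol-1-yl would fare.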